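A Methylamino Group in Place of a Propoxy on the Carbonyl

The compounds below may be only part of what the source reports. "The series", "measured", "known", "first", "only" and "open" are said of these compounds alone.

Of the compounds shown here, three built on one shared core have been tested in a functional assay on MDA-MB-231 cells (Homo sapiens) for cytotoxicity, read by MTT assay, with a stated time of 72 h; a higher number here means that more compound is needed for the effect, a lower number that less compound is needed. Compound 1 `CCOc1c(-c2occ(C)c2C(=O)O)ccc2c(CC)cccc12` gives only a limit in this assay, > 10 ug/mL. Compound 2 `CCOC(=O)c1c(C)coc1-c1ccc2c(CC)cccc2c1OC` gives 3.9 ug/mL in this assay. Compound 3 `CCCOC(=O)c1c(C)coc1-c1ccc2c(CC)cccc2c1OC` likewise gives only a limit in this assay, > 10 ug/mL. Within the data shown here, the single step between measured compounds that differ in one place is an at least 2.5-fold higher number from compound 2 to compound 3 (0.40 log units; beyond the scatter). Compound 3 therefore stands at the edge of what this assay reports, with no number of its own, and it shares that position with compound 1 because of the limit of > 10 ug/mL in this assay, at which 2 of the 3 values shown sit.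

Compound 4 `CCc1cccc2c(OC)c(-c3occ(C)c3C(=O)NC)ccc12` differs from compound 3 by methylamino in place of propoxy on a carbonyl carbon; cut one bond further out, the change reads propoxycarbonyl to methylcarbamoyl. Among the measured compounds shown here, no measured step follows this kind of change. For the measured compounds named here, the only measured step, an at least 2.5-fold higher number from compound 2 to compound 3 (0.40 log units; beyond the scatter), concerns a different alteration and ends at a limit, so it sets no direction for compound 4. With compound 3 already at the limit, compound 4 is expected to give a number at or near that limit, and the expected step of an at least 1.1-fold lower number from compound 3 to compound 4 (0.04 log units; that floor lies within the scatter) is taken as none beyond the scatter. Compound 4 is estimated at 9 ug/mL, within a range from 3 ug/mL to 30 ug/mL.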

Compound 4, concentration for half-maximal effect: > 10 ug/mL
Compound 4 ended at the assay's limit; the forecaster's own chance of this, stated with the estimate: 55%; at least 1.1-fold (0.04 log units) between middle value and limit.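

Compound 2 now has a second partner in a one-place change at this carbonyl carbon: methylamino in place of ethoxy gives an at least 2.5-fold higher number from compound 2 to compound 4 (0.40 log units; beyond the scatter), and that step ends at a limit of this assay, not at a number. So the loss of a readable value seen earlier with propoxy is not confined to a longer alkoxy chain, since it also appears with a group joined through nitrogen, which brings a hydrogen-bond donor that neither ethoxy nor propoxy has. Among the groups tried on this carbonyl carbon, only ethoxy in compound 2 gives a number, and the step between compound 3 and compound 4 cannot be read, so propoxy and methylamino cannot be ranked, and most of the set now sits at one edge of the assay: the limit of > 10 ug/mL in this assay, at which 3 of the 4 values shown sit.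

On these data alone, how far past that limit compound 3 and compound 4 lie remains unknown, so the size of either loss has no upper bound. Also open, as far as these compounds go, is whether a methoxy, a plain amino group or a dimethylamino group on the same carbonyl carbon would give a number in this assay, and how that number would compare with the value of compound 2.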